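This account rests on a few compounds, and the source may have more. Where it says the series, first, only, none or still open, it means among the compounds named here.

Measured compounds in a functional assay on A549 cells (Homo sapiens) for antiproliferative activity, read by MTT assay, with a stated time of 48 h; a higher number here means a weaker inhibitor, a lower number a stronger inhibitor:
- Compound 1 `N#CC1=C(N)Oc2c(c3nc4ccccc4nc3c3ccccc23)C12C(=O)N(Cc1cnnn1-c1ccc(F)cc1)c1ccccc12` gives > 50000 nM, which is a limit of the assay and not a number.
- Compound 2 `N#CC1=C(N)Oc2c(c3nc4ccccc4nc3c3ccccc23)C12C(=O)N(Cc1cnnn1-c1ccccc1Br)c1ccccc12` gives > 50000 nM, again a limit of the assay.
- Compound 3 `N#CC1=C(N)Oc2c(N)cc3nc4ccccc4nc3c2C12C(=O)N(Cc1cnnn1-c1ccccc1Cl)c1ccccc12` gives 29800 nM.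

For the measured compounds named here, compound 3 thus holds the only real number among the three; the other two results sit at the limit of > 50000 nM in this assay, at which 2 of the 3 values shown sit. Going by the values given here, the one step between measured compounds that differ in a single place, a step that the two limits leave unreadable from compound 1 to compound 2, cannot be sized, since both ends are limits.

Compound 4 `Cc1cc(C)cc(-n2nncc2CN2C(=O)C3(C(C#N)=C(N)Oc4c(N)cc5nc6ccccc6nc5c43)c3ccccc32)c1` differs from compound 3 only at the group on an aromatic nitrogen of a five-membered aromatic ring with 3 nitrogen: 3,5-dimethylphenyl in place of 2-chlorophenyl on an aromatic nitrogen. Among the compounds with values here, no measured step reads on such a swap, so there is no basis to expect a change beyond the usual scatter of this assay. Compound 4 is therefore expected to give about 30000 nM, within roughly 10000 nM to 90000 nM, meaning an estimated step of a 1.0-fold higher number from compound 3 to compound 4 (0.00 log units; within the scatter), with a real chance that only a limit is reported.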

Compound 4, half-maximal inhibitory concentration: 31200 nM
Compound 4: middle estimate off by 1.0-fold (0.02 log units), on the low side; the measured number falls inside the stated range.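

For the compounds shown here, putting 3,5-dimethylphenyl in place of 2-chlorophenyl gives, in this assay, a 1.0-fold higher number from compound 3 to compound 4 (0.02 log units; within the scatter), the first change on this aromatic nitrogen whose size can be read. For this one pair, the two substituted phenyl groups cannot be told apart, so exchanging a chlorine for two methyl groups on that ring leaves the result within the scatter. The earlier step at this position, on the core of compound 1 and compound 2, cannot be read, as both of its ends are limits: the limit of > 50000 nM in this assay, at which 2 of the 4 values shown sit.

Going by these compounds, whether a phenyl ring carrying an amine or a carboxylic acid would give a step beyond the scatter remains open. So does the effect of a longer chain in place of the phenyl group on the core of compound 3.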